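Bromo in place of chloro in compound 2

This account rests on a few compounds, and the source may have more. Where it says the series, first, only, none or still open, it means among the compounds named here.

- compound 1 `O=C1C(=Cc2ccc(O)cc2)C(=O)N(c2ccc(Cl)cc2)N1c1ccc(Cl)cc1` with 20600 nM
- compound 2 `O=C1C(=Cc2ccc(Cl)cc2)C(=O)N(c2ccc(Cl)cc2)N1c1ccc(Cl)cc1` with 30900 nM

In a functional assay on SMMC-7721 cells (Homo sapiens) for cytotoxicity, read by MTT assay, with a stated time of 72 h (a lower number here means a stronger inhibitor, a higher number a weaker inhibitor), compound 2 stands at 30900 nM and lies within the scatter of compound 1. Compound 3 `O=C1C(=Cc2ccc(Br)cc2)C(=O)N(c2ccc(Cl)cc2)N1c1ccc(Cl)cc1` differs from compound 2 in one place, with bromo in place of chloro on an aromatic carbon, para to a large group. Among the measured compounds shown here, one measured step bears on this, also a change on an aromatic carbon: chloro in place of hydroxy (a 1.5-fold higher number from compound 1 to compound 2 (0.18 log units; within the scatter)) stayed within the scatter. For the measured compounds named here, no bromo compound has been measured, so this evidence is thin. On that single step, no change beyond the scatter is expected in this assay for compound 3. The estimated step reads a 1.0-fold lower number from compound 2 to compound 3 (0.01 log units; within the scatter) in this expectation. Compound 3 is expected at 30000 nM with an estimated range of 15000 nM to 60000 nM as the likely span.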

Compound 3, half-maximal inhibitory concentration: 16600 nM
Compound 3: the middle estimate sits 1.8-fold (0.26 log units) above what was measured, and the stated range covers the measured number.
By their numbers in this assay, from the lowest: compounds 3, 1 and 2 (each within the scatter of the next).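

In this assay, bromo in place of chloro on this aromatic carbon, para to a large group, gives a 1.9-fold lower number from compound 2 to compound 3 (0.27 log units; within the scatter), so this first exchange of one halogen for another leaves the reading within the scatter. Bromo in place of hydroxy on the same carbon gives a 1.2-fold lower number from compound 1 to compound 3 (0.09 log units; within the scatter), also within the scatter, and so hydroxy, chloro and bromo at this position cannot be told apart in this cell read-out. No measurement at hand offers an explanation for this flat reading.

The compounds shown leave open whether an amine, a carboxylic acid or a longer chain on this carbon would move the number beyond the scatter. They also leave open what happens when the two 4-chlorophenyl groups on the shared core carry another group.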